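One Changed Stereocentre and the Expected Shift for Compound 4

The source may report more compounds than this note shows. Statements on the series, on what has been measured and on what is new or still open speak of the compounds shown alone.

In a functional assay on KB cells (Homo sapiens) for cytotoxicity, read by colorimetric assay and neutral red uptake, with a stated time of 72 h (a higher number here means a weaker inhibitor, a lower number a stronger inhibitor), compound 1 (`CO[C@@H](C(=O)N[C@H]1CCCCNC1=O)[C@H](O)[C@@H](O)[C@H](O)/C=C/C(C)(C)C`) gives 21000 nM, and compound 2 (`CO[C@@H](C(=O)N[C@@H]1CCCCNC1=O)[C@H](O)[C@@H](O)[C@H](O)/C=C/C(C)(C)C`) gives 1100 nM. Compound 3 (`CO[C@@H](C(=O)N[C@H]1CC[C@H](O)CNC1=O)[C@H](O)[C@@H](O)[C@H](O)/C=C/C(C)(C)C`) gives 19800 nM, which lies within the scatter of compound 1 and far from compound 2, with an 18-fold higher number from compound 2 to compound 3 (1.26 log units; beyond the scatter). Placing a hydroxy group on the ring of compound 1 leaves the number essentially level, with a 1.1-fold lower number from compound 1 to compound 3 (0.03 log units; within the scatter).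

Compound 4 (`CO[C@@H](C(=O)N[C@@H]1CC[C@H](O)CNC1=O)[C@H](O)[C@@H](O)[C@H](O)/C=C/C(C)(C)C`) has not yet been measured. Its relation to compound 3 is simple: the two compounds have the same atoms and bonds and differ only in configuration as drawn: 1 of 7 stereo elements differ; a stereocentre at a saturated ring carbon is drawn S in compound 3 and R in compound 4. Among the compounds with values here, the closest precedent is the same kind of change without the hydroxy group, a 19-fold lower number from compound 1 to compound 2 (1.28 log units; beyond the scatter), a large step due to the fact that compounds 1 and 2 differ only in the configuration as drawn. A fall of similar size is therefore expected in this assay, an estimated 15-fold lower number from compound 3 to compound 4 (1.18 log units; beyond the scatter). From the compounds shown here alone, whether the step carries over fully to the hydroxy-bearing ring is untested, so the range is kept wide. For compound 4 the expected value is 1300 nM, with an estimated range from 300 nM to 6500 nM.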

Compound 4, half-maximal inhibitory concentration: 23700 nM
Estimate against measurement, compound 4: 18-fold (1.26 log units) below, outside the stated range (above it).
By their numbers in this assay, from the lowest: compound 2; then compounds 3, 1 and 4 (each within the scatter of the next).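

In this assay, the effect of the ring stereocentre depends on what else the ring carries: with the hydroxy group present, the same inversion gives a 1.2-fold higher number from compound 3 to compound 4 (0.08 log units; within the scatter), and the large drop seen without that group does not appear. The hydroxy group is tolerated only on one stereochemical background, since adding it to the more active compound 2 gives a 22-fold higher number from compound 2 to compound 4 (1.33 log units; beyond the scatter), while the replacement by 6-hydroxy-2-oxoazepan-3-yl on the other configuration gives a 1.1-fold higher number from compound 1 to compound 4 (0.05 log units; within the scatter). The two changes therefore do not simply add up, as the hydroxy change shows on its two cores: the same change on two cores in this assay, a 1.1-fold lower number (0.03 log units; within the scatter) from compound 1 to compound 3 and a 22-fold higher number (1.33 log units; beyond the scatter) from compound 2 to compound 4, 23-fold (1.36 log units) apart, beyond the scatter of two such steps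

From the compounds shown here alone, only one drawn configuration of the hydroxy-bearing ring carbon appears here, so the effect of the opposite one remains open. Also open, going by these compounds, is whether a methoxy group or an amine on that carbon would erase the advantage of compound 2 in the same way.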